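Chloro in Place of Fluoro on a Measured Pair

A few compounds are considered here, and "the series" means these few. Any claim that something is new, unique, unknown or untested is made for them only; others in the source may bear on it.

Compound 1: `N=C(N)c1ccc(-c2ccc(-c3cncc4ccccc34)s2)s1`, 1690 nM
Compound 2: `N=C(N)c1ccc(-c2ccc(-c3ccc(F)cc3)o2)o1`, 1900 nM

Of the compounds shown here, two have been measured in a functional assay on A498 cells (Homo sapiens) for inhibition, read by sulforhodamine B assay, with a stated time of 48 h; on this read-out higher numbers stand for weaker inhibition of growth and lower numbers for stronger inhibition of growth. Compound 1 gives 1690 nM there, and compound 2 gives 1900 nM in this assay. For the measured compounds named here, the two numbers lie within the scatter of each other, so compound 2 cannot be set apart from compound 1 on these results; no single-point step between measured compounds is available.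

Compound 3, `N=C(N)c1ccc(-c2ccc(-c3ccc(Cl)cc3)o2)o1`, has not yet been measured. It differs from compound 2 in one place: chloro in place of fluoro on an aromatic carbon. The change is small in what is counted, and nothing measured here shows what such a swap does in this assay. The step from compound 2 to compound 3 is therefore expected to be no larger than the scatter, with no direction favoured, giving a 1.3-fold lower number from compound 2 to compound 3 (0.10 log units; within the scatter). Compound 3 is estimated at 1500 nM, within a range from 600 nM to 4000 nM.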

Compound 3, concentration for 50% growth inhibition: 2120 nM
Beside the measured number, compound 3's estimate is 1.4-fold (0.15 log units) below it; the measured number falls inside the stated range.
By their numbers in this assay, from the lowest: compounds 1, 2 and 3 (each within the scatter of the next).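

In this assay, chloro in place of fluoro on an aromatic carbon, para to a large group, gives a 1.1-fold higher number from compound 2 to compound 3 (0.05 log units; within the scatter). For the compounds shown here, this is the first single-place step available, and it shows that this exchange of one halogen for the other at this position cannot be told from no change. Nothing available bears on why the two halogens read alike.

Still open, on these data alone, is whether a group of another kind at this place, such as an amine, a carboxylic acid or a methoxy group, would move the number beyond the scatter, and whether plain hydrogen would do so. The step also comes from a single pair on one core, so it says nothing about the same exchange on any other core.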